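The compounds below may be only part of what the source reports. "The series", "measured", "known", "first", "only" and "open" are said of these compounds alone.

In a functional assay on HeLa cells (Homo sapiens) for cytotoxicity, read by WST assay, with a stated time of 48 h (a lower number here means a stronger inhibitor, a higher number a weaker inhibitor), compound 1 `COc1ccc(/C=C/C[C@H]2C[C@@H]([C@@H](O)c3ccccc3)CO[C@@H]2c2ccccc2)cc1` gives 8300 nM. Among the compounds with values here, compound 2 `O=[N+]([O-])c1cccc(/C=C/C[C@H]2C[C@@H]([C@@H](O)c3ccccc3)CO[C@@H]2c2ccccc2)c1` gives 7850 nM, which lies within the scatter of the value for compound 1, and these are the only two numbers known so far. Compound 3 `O=[N+]([O-])c1ccc(/C=C/C[C@H]2C[C@@H]([C@@H](O)c3ccccc3)CO[C@@H]2c2ccccc2)cc1` has the same atoms as compound 2, joined differently, with 4-nitrophenyl in place of 3-nitrophenyl on a double-bonded chain carbon bound to a double-bonded chain carbon. Within the data shown here, no measured step covers this exact swap. The nearest guide is the change of group at the same place, a 1.1-fold lower number from compound 1 to compound 2 (0.02 log units; within the scatter), and it stayed within the scatter. Among the measured compounds shown here, with only that small step to go on, no shift beyond the scatter is expected in this assay. The estimated step is a 1.0-fold lower number from compound 2 to compound 3 (0.02 log units; within the scatter). For compound 3 the expected value is 7500 nM, with an estimated range of 3500 nM to 15000 nM.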

Compound 3, half-maximal inhibitory concentration: 12400 nM
For compound 3 the middle estimate is 1.7-fold (0.22 log units) below the measured one, within the range that was stated.
By their numbers in this assay, from the lowest: compounds 2, 1 and 3 (each within the scatter of the next).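

In this assay, 4-nitrophenyl in place of 3-nitrophenyl on a double-bonded chain carbon bound to a double-bonded chain carbon gives a 1.6-fold higher number from compound 2 to compound 3 (0.20 log units; within the scatter) and so, in this pair, moving the nitro group around the ring produces no change that can be told from the scatter. Nitro in place of methoxy on an aromatic carbon gives a 1.5-fold higher number from compound 1 to compound 3 (0.17 log units; within the scatter) and this second direct comparison also stays inside the scatter, so 4-methoxyphenyl, 3-nitrophenyl and 4-nitrophenyl cannot be told apart here. No supporting evidence is available to explain this result.

On these data alone, it remains open whether a different kind of group on this ring, such as an amine or a carboxylic acid, would shift the number beyond the scatter. As far as these compounds go, it is also open whether a longer chain joining this ring to the shared core would do so.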